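The compounds below may be only part of what the source reports. "The series", "measured", "known", "first", "only" and "open" are said of these compounds alone.

Measured compounds in an assay on membranes from lung (Cavia porcellus) for binding affinity to cysteinyl leukotriene receptor (Homo sapiens); a higher number here means a weaker inhibitor, a lower number a stronger inhibitor:
- compound 1 `O=C(O)CC1CCCC1Cc1ccc(OCc2ccc3ccccc3n2)cc1`: 100 nM
- compound 2 `c1ccc2nc(COc3ccc(CC4CCCC4Cc4nnn[nH]4)cc3)ccc2c1`: 15 nM
- compound 3 `CCCC(CCc1nnn[nH]1)Cc1cccc(OCc2ccc3ccccc3n2)c1`: 11 nM

Compound 1 gives the highest number of the three; its nearest neighbour is compound 2 and the furthest is compound 3, both beyond the scatter.

The unmeasured compound 4 `CC(CCc1nnn[nH]1)Cc1ccc(OCc2ccc3ccccc3n2)cc1` differs from compound 1 as follows: 3-(1H-tetrazol-5-yl)-1-methylpropyl in place of 2-(carboxymethyl)cyclopentyl on a saturated chain carbon bound to an aromatic carbon. The change bundles two things: the carboxy-to-tetrazole swap seen in a 6.7-fold lower number from compound 1 to compound 2 (0.82 log units; beyond the scatter), which was modest but beyond the scatter, and the opening of the five-membered ring into a branched chain. Within the data shown here, for the ring opening no single-change step exists; compound 3 carries an open 1H-tetrazol-5-yl chain with a different branch and a different attachment to the shared core, and its value of 11 nM sits within the scatter of compound 2, so the open chain on its own gives no sign of costing affinity. The expected step of a 5.0-fold lower number from compound 1 to compound 4 (0.70 log units; beyond the scatter) is therefore a lowering of about the size of the tetrazole swap, with added uncertainty from the second change. Compound 4 is estimated at 20 nM in this assay, expected to fall between 6 nM and 70 nM.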

Compound 4, inhibition constant: 12 nM
Estimate against measurement, compound 4: 1.7-fold (0.22 log units) above, within the range that was stated.
By their numbers in this assay, from the lowest: compounds 3, 4 and 2 (each within the scatter of the next); then compound 1.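

In this assay, 3-(1H-tetrazol-5-yl)-1-methylpropyl in place of 2-(carboxymethyl)cyclopentyl, on a saturated chain carbon bound to an aromatic carbon, gives an 8.3-fold lower number from compound 1 to compound 4 (0.92 log units; beyond the scatter), so the lower number also holds without the five-membered ring of carbon only. With a 1H-tetrazol-5-yl group in both, compound 2 with that ring gives 15 nM and compound 4 without it gives 12 nM, two values within the scatter of each other, so keeping the ring is not needed for a number of this size in these two compounds. No measurement shown explains the size of the step.

The step bundles the ring opening with the change of acid group, and the open chain ending in a carboxylic acid would be needed to separate them. As far as these compounds go, the role of the methyl branch also stays open, as an unbranched chain would show.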